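The compounds below may be only part of what the source reports. "The series", "measured", "known", "first", "only" and "open" are said of these compounds alone.

Measured compounds in an assay on isolated protein for inhibition of 2-Hydroxyacid oxidase 2 (Rattus norvegicus); on this read-out higher numbers stand for weaker inhibition and lower numbers for stronger inhibition:

Compound 1 `Cc1n[nH]c(C(=O)O)c1Cc1cccc(-c2ccc(OC(F)(F)F)cc2)c1` gives 300 nM.
Compound 2 `Cc1n[nH]c(C(=O)O)c1Cc1cccc(-c2ccc(C(F)(F)F)cc2)c1` gives 400 nM.
Compound 3 `Cc1n[nH]c(C(=O)O)c1Cc1ccc(-c2ccc(C(F)(F)F)cc2)cc1` gives 1100 nM.

Compound 1 and compound 2 share one core and differ only at a single spot on the outer ring: trifluoromethoxy in place of trifluoromethyl on an aromatic carbon. This change gave a 1.3-fold lower number from compound 2 to compound 1 (0.12 log units; within the scatter), so the two compounds cannot be told apart on this assay.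

Compound 3 has the same atoms as compound 2, joined differently; the difference between the two cores is not broken down here. Compound 3 stands highest of the three measured numbers, beyond the scatter from both compound 2 and compound 1, so on this assay compound 3 is the weakest inhibitor of the three.

Compound 4 `Cc1n[nH]c(C(=O)O)c1Cc1ccc(-c2ccc(OC(F)(F)F)cc2)cc1` is not yet measured. It comes from compound 3 by the same change that led from compound 2 to compound 1: trifluoromethoxy in place of trifluoromethyl on an aromatic carbon. The place described around the change is the same in both pairs. Because the earlier change gave a 1.3-fold lower number from compound 2 to compound 1 (0.12 log units; within the scatter), the step from compound 3 to compound 4 is expected to be small as well, about a 1.3-fold lower number from compound 3 to compound 4 (0.11 log units; within the scatter). Compound 4 is therefore estimated to give 850 nM, with a likely range from 450 nM to 1600 nM.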

Compound 4, half-maximal inhibitory concentration: 2000 nM
Beside the measured number, compound 4's estimate is 2.4-fold (0.37 log units) below it; measured number above the stated range.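

Putting trifluoromethoxy in place of trifluoromethyl in this assay gave a 1.8-fold higher number from compound 3 to compound 4 (0.26 log units; within the scatter), so on this core too the two compounds cannot be told apart. Set side by side, the two steps do not differ by more than the scatter allows, and in both pairs the change is a small step: the same change on two cores in this assay, a 1.3-fold lower number (0.12 log units; within the scatter) from compound 2 to compound 1 and a 1.8-fold higher number (0.26 log units; within the scatter) from compound 3 to compound 4, 2.4-fold (0.38 log units) apart, within the scatter of two such steps. This does not show that the change acts identically on both cores, or that it would stay small on a third core, for two pairs with steps this small could still hide a modest real difference.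

The compounds shown leave open what other groups would do at the same place on the outer ring, such as a nitrile, an amine or a longer chain. They also leave open whether a group of that kind would give a step large enough to stand clear of the scatter in this assay, and whether such a step would then carry from one core to the other.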